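The source may report more compounds than this note shows. Statements on the series, on what has been measured and on what is new or still open speak of the compounds shown alone.

Working notes on the series.

Of the compounds shown here, two carry a number so far. Compound 1 `O=C(Nc1cccc(-n2cc(-c3ccncc3)c(-c3cc(O)cc(Cl)c3)n2)c1)Nc1ccc(Cl)c(Cl)c1` gives 98% in a functional assay on SF-268 cells (Homo sapiens) for inhibition, read by sulforhodamine B assay, with a stated time of 48 h, tested at 0.1 uM; a lower number here means a stronger effect, a higher number a weaker effect of the compound at the concentration tested. For the measured compounds named here, compound 2 `COc1cc(Cl)cc(-c2nn(-c3cccc(NC(=O)Nc4ccc(Cl)c(Cl)c4)c3)cc2-c2ccncc2)c1` gives 95% in this assay, which is the lowest of the two numbers, though its only neighbour, compound 1, sits within the usual scatter of it; the single step recorded, a number 3 percentage points lower from compound 1 to compound 2 (within the scatter), is methyl in place of hydrogen on an oxygen on an aromatic ring.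

The next compound to go into this assay is compound 3 `COc1cc(Cl)cc(-c2nn(-c3cccc(NC(=O)c4cccc(C(F)(F)F)c4)c3)cc2-c2ccncc2)c1`. It differs from compound 2 as follows: 3-(trifluoromethyl)phenyl in place of (3,4-dichlorophenyl)amino on a carbonyl carbon. Going by the values given here, the change sits on the carbonyl carbon whose other neighbour is an amide-type nitrogen, on the (3,4-dichlorophenyl)carbamoyl side, and so lies on a different part of the molecule from the one step measured. That step stayed within the scatter and bears on this change only as a sign that the shared core tolerates small edits. Among the compounds with values here, no measured pair speaks directly to the replacement, so the expectation rests on compound 2 alone.

Compound 3 is therefore expected to land near compound 2, at an estimated 92%, with a range from 75% to 100%, the expected step of a number 3 percentage points lower from compound 2 to compound 3 (within the scatter) being one of no clear direction beyond the scatter.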

Compound 3, a percentage reported as activity, at one concentration (the size of the read-out at that concentration, not a potency): 100%
Compound 3: middle estimate off by 8 percentage points, on the low side, and the stated range covers the measured number.
By their numbers in this assay, from the lowest: compounds 2, 1 and 3 (each within the scatter of the next).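

For the compounds shown here, at this carbonyl carbon, 3-(trifluoromethyl)phenyl in place of (3,4-dichlorophenyl)amino gives a number 5 percentage points higher from compound 2 to compound 3 (within the scatter) in this assay, the first reading at this place in the molecule. Going by these compounds alone, the exchange is not a small one: it removes the nitrogen that joined the carbonyl carbon to the aromatic ring, and the hydrogen-bond donor counted on the leaving group has no counterpart on the entering group, yet this read-out at this single concentration does not separate compound 2 from compound 3. Nothing available bears on why the number stays within the scatter, so this result gives no explanation for the step.

Still open, from the compounds shown here alone, is whether any group on this carbonyl carbon can move the number beyond the scatter, for example a morpholine ring, a carboxylic acid on the aromatic ring or a plain ethyl chain in place of 3-(trifluoromethyl)phenyl. Equally open, going by these compounds, is whether compound 2 and compound 3 would separate at a higher concentration, which a reading at one concentration cannot show.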